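The source may hold more compounds than are shown below. What is called first, only, known or untested is meant among the compounds shown, and "the series" means these compounds.

Working notes on the series. For the measured compounds named here, compound 2 `CCn1cc(-c2nc3ccccc3s2)c(=O)c2cc(F)c(N3CCNCC3)nc21` gives 2700 nM in a functional assay on A2780 cells (Homo sapiens) for cytotoxicity, read by MTT assay, with a stated time of 48 h (a higher number here means a weaker inhibitor, a lower number a stronger inhibitor), and has the lowest of the three numbers measured so far; compound 1 `CCn1cc(-c2nc3ccccc3[nH]2)c(=O)c2cc(F)c(N3CCNCC3)nc21` gives 4800 nM, and the step of a 1.8-fold lower number from compound 1 to compound 2 (0.25 log units; within the scatter) stays within the scatter, so the two cannot be ordered. Compound 3 `CCn1cc(-c2nc3ccc(Cl)cc3[nH]2)c(=O)c2cc(F)c(N3CCNCC3)nc21` gives 6300 nM; the step of a 2.3-fold higher number from compound 2 to compound 3 (0.37 log units; beyond the scatter) is the only one beyond the scatter, while a 1.3-fold higher number from compound 1 to compound 3 (0.12 log units; within the scatter) is not.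

Compound 4 `CCn1cc(-c2nc3ccc([N+](=O)[O-])cc3s2)c(=O)c2cc(F)c(N3CCNCC3)nc21` differs from compound 2 by nitro in place of hydrogen on an aromatic carbon. The closest measured step is a 1.3-fold higher number from compound 1 to compound 3 (0.12 log units; within the scatter), a substituent entering a ring carbon of a different fused ring system, and it did not move the number beyond the scatter. Going by the values given here, no step with nitro is available, and the only substituent step measured sits on the core of compound 1 rather than compound 2, so the bearing is indirect. The expectation is therefore a step of a 1.1-fold higher number from compound 2 to compound 4 (0.05 log units; within the scatter), with no clear direction beyond the scatter. Compound 4 is estimated at 3000 nM, within 1300 nM to 7000 nM.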

Compound 4, half-maximal inhibitory concentration: 200000 nM
Compound 4: middle estimate off by 67-fold (1.82 log units), on the low side; measured number outside the range, above it.
By their numbers in this assay, from the lowest: compounds 2, 1 and 3 (each within the scatter of the next, the first and the last beyond it); then compound 4.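

In this assay the step of a 74-fold higher number from compound 2 to compound 4 (1.87 log units; beyond the scatter) shows that this aromatic carbon of the core of compound 2 does not tolerate every replacement of hydrogen: nitro here moves the number far beyond the scatter. For the compounds shown here, the only other substituent step a 1.3-fold higher number from compound 1 to compound 3 (0.12 log units; within the scatter) stays within the scatter, but it has chloro on the core of compound 1, so the two steps differ in both group and core and cannot show which of these sets their contrast. Nothing measured here gives a reason for the size of the nitro step.

From the compounds shown here alone, whether this step belongs to nitro itself or would follow any group on this carbon remains open. An amino group, a methyl group or chloro at the same place on the core of compound 2 would separate these two readings.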